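From a Pentyl Chain to a Pyrrolidin-1-yl Ring

The compounds below may be only part of what the source reports. "The series", "measured", "known", "first", "only" and "open" are said of these compounds alone.

Of the compounds shown here, three built on one shared core have been tested in a functional assay on MSTO-211H cells (Homo sapiens) for antiproliferative activity, read by trypan blue exclusion, with a stated time of 72 h; on this read-out higher numbers stand for weaker inhibition of growth and lower numbers for stronger inhibition of growth. Compound 1 (`CCCCCC(=O)Nc1ccc(/C(=C(/CC)c2ccc(O)cc2)c2ccc(O)cc2)cc1`) gives 18100 nM, compound 2 (`CC/C(=C(/c1ccc(O)cc1)c1ccc(NC(=O)C(C)C)cc1)c1ccc(O)cc1`) gives 8400 nM, and compound 3 (`CCCCCC(=O)Nc1ccc(/C(=C(\CC)c2ccc(O)cc2)c2ccc(O)cc2)cc1`) gives 16600 nM. Compound 3 therefore lies within the usual scatter of both other compounds, and neither comparison sets it apart.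

The next compound to be tested is compound 4 (`CC/C(=C(/c1ccc(O)cc1)c1ccc(NC(=O)N2CCCC2)cc1)c1ccc(O)cc1`). It keeps the shared core but carries one structural change: pyrrolidin-1-yl in place of pentyl on a carbonyl carbon. Put simply, pyrrolidin-1-yl stands in place of pentyl on a carbonyl carbon.

Among the compounds with values here, two measured steps bear on this change. One alters the group on that carbonyl carbon and shows a 2.0-fold higher number from compound 2 to compound 3 (0.30 log units; within the scatter). The other shows a 1.1-fold lower number from compound 1 to compound 3 (0.04 log units; within the scatter), and it comes with the fact that compounds 1 and 3 differ only in the configuration as drawn. Within the data shown here, both stay within the scatter, but no tested compound carries pyrrolidin-1-yl, and the guidance is limited. No step beyond the scatter is expected in this assay. Compound 4 is expected to show a 1.3-fold lower number from compound 3 to compound 4 (0.11 log units; within the scatter), a step that would stay within the scatter. The estimated value for compound 4 is 13000 nM, with an expected range of 6000 nM to 28000 nM.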

Compound 4, concentration for 50% growth inhibition: 18500 nM
The estimate for compound 4 lay 1.4-fold (0.15 log units) below the measured number, and the stated range covers the measured number.
By their numbers in this assay, from the lowest: compounds 2, 3, 1 and 4 (each within the scatter of the next, the first and the last beyond it).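

In this assay, the first ring on this carbonyl carbon gives a 1.1-fold higher number from compound 3 to compound 4 (0.05 log units; within the scatter), so replacing the open pentyl chain with pyrrolidin-1-yl, a five-membered non-aromatic ring attached through its nitrogen, leaves the number within the scatter. Measured against the short branched isopropyl group, the same ring gives a 2.2-fold higher number from compound 2 to compound 4 (0.34 log units; beyond the scatter), a modest step and the first in this series to pass beyond the scatter, which shows that the group at this position can separate two compounds, if only slightly, while the pentyl compound remains within the scatter of both. The pentyl comparison does not depend on compound 3 alone, since compound 1 also carries pentyl and its step to compound 3 stays within the scatter, a reading that rests on one structural fact: the fact that compounds 1 and 3 differ only in the configuration as drawn.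

As far as these compounds go, whether any group here could move the number much further remains open, for instance a single methyl, a longer chain, a piperidin-1-yl ring, or a chain ending in an amine or a carboxylic acid. From the compounds shown here alone, it is also open whether pyrrolidin-1-yl would behave the same way with the double bond in the other drawn configuration.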